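From an open chain to a pyrazole ring

The source may hold more compounds than are shown below. What is called first, only, known or untested is meant among the compounds shown, and "the series" means these compounds.

In an ADME assay on NIH3T3 cells (Mus musculus) for cytotoxicity, read by MTT assay, with a stated time of 72 h (on this read-out higher numbers stand for weaker inhibition and lower numbers for stronger inhibition), compound 1 `COc1ccc(/C=C/c2cc(C)no2)cc1OC` gives 93200 nM, while compound 2 `COc1ccc(/C=C/C(=O)CC(C)=O)cc1OC` gives 18100 nM, the lower of the two numbers. Compound 3 `COc1ccc(/C=C/c2cc(C)n[nH]2)cc1OC` differs from compound 2 by one change, with 3-methyl-1H-pyrazol-5-yl in place of (2-oxopropyl)carbonyl on a double-bonded chain carbon bound to a double-bonded chain carbon. Among the compounds with values here, the only measured step bearing on this is the modest 5.1-fold lower number from compound 1 to compound 2 (0.71 log units; beyond the scatter), where (2-oxopropyl)carbonyl took the place of 3-methyl-1,2-oxazol-5-yl. Compound 3 restores a five-membered aromatic ring there, so a similar or somewhat smaller step toward higher numbers is expected in this assay. The expected change is a 2.8-fold higher number from compound 2 to compound 3 (0.44 log units; beyond the scatter). Compound 3 is estimated at 50000 nM, within a range of 18000 nM to 130000 nM.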

Compound 3, half-maximal inhibitory concentration: 68400 nM
Compound 3: middle estimate off by 1.4-fold (0.14 log units), on the low side; the measured number falls inside the stated range.
By their numbers in this assay, from the lowest: compound 2; then compounds 3 and 1 (each within the scatter of the next).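

In this assay, replacing the open (2-oxopropyl)carbonyl chain with 3-methyl-1H-pyrazol-5-yl gives a 3.8-fold higher number from compound 2 to compound 3 (0.58 log units; beyond the scatter), so at this place the lower number stays with the open chain among these structures. Exchanging 3-methyl-1,2-oxazol-5-yl for 3-methyl-1H-pyrazol-5-yl gives a 1.4-fold lower number from compound 1 to compound 3 (0.13 log units; within the scatter), so these two rings are not separated here. No measurement offers an explanation for either step. As far as these compounds go, it remains open whether a carboxylic acid or an acetyl group on the double-bonded chain carbon would give a number like that of the open chain or like those of the two rings.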